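This account rests on a few compounds, and the source may have more. Where it says the series, first, only, none or still open, it means among the compounds named here.

Working notes on the series. Compound 1 `Cc1cc(C(=O)O)ccc1CN1CCC[C@H](O[C@H](CO)c2cc(Cl)cc(Cl)c2)[C@@H]1c1ccc(F)cc1` in an assay on isolated protein for activation of cGMP-dependent protein kinase 1 (Homo sapiens), read by ADP-Glo, with stated times of 30 min and 2 h, in the presence of a further agent that is not named here (on this read-out higher numbers stand for an effect only at larger amounts of compound and lower numbers for an effect already at smaller amounts), gives 18000 nM. Compound 2 `Cc1cc(C(=O)O)ccc1CN1CCC[C@H](OC(c2cc(Cl)cc(Cl)c2)C(C)O)[C@@H]1c1ccccc1`, which is not linked to the others by any single-point step, gives 5300 nM in this assay. Compound 3 `Cc1cc(C(=O)O)ccc1CN1CCC[C@H](O[C@H](CO)c2cc(Cl)cc(Cl)c2)[C@@H]1c1ccccc1F` gives 2600 nM in this assay, the lowest of the three numbers; compound 2 is nearest and compound 1 furthest, both gaps beyond the scatter. Going by the values given here, the only single-point step within the measured set is a 6.9-fold lower number from compound 1 to compound 3 (0.84 log units; beyond the scatter), a modest change.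

Compound 4 `Cc1cc(C(=O)O)ccc1CN1CCC[C@H](O[C@H](CO)c2cc(Cl)cc(Cl)c2)[C@@H]1c1cccc(F)c1` has not yet been measured in this assay. It differs from compound 3 in one place: 3-fluorophenyl in place of 2-fluorophenyl on a saturated ring carbon. The step from compound 1 to compound 3 bears on this change: it too exchanges one fluorophenyl for another on a saturated ring carbon of the shared core. Among the compounds with values here, there, 4-fluorophenyl gave the highest number and 2-fluorophenyl the lowest, so 3-fluorophenyl is expected to fall between them, a modest rise from compound 3, though no second example fixes its size. The expected step in this assay is a 2.3-fold higher number from compound 3 to compound 4 (0.36 log units; beyond the scatter). Compound 4 is estimated in this assay at 6000 nM, with a range of 2500 nM to 15000 nM.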

Compound 4, half-maximal effective concentration: 12000 nM
For compound 4 the middle estimate is 2.0-fold (0.30 log units) below the measured one; low and high end bracket the measured number.
By their numbers in this assay, from the lowest: compound 3; then compound 2; then compounds 4 and 1 (each within the scatter of the next).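

In this assay, the step of a 4.6-fold higher number from compound 3 to compound 4 (0.66 log units; beyond the scatter) shows that the low number of compound 3 does not carry over to the 3-fluorophenyl group at this saturated ring carbon. The step of a 1.5-fold lower number from compound 1 to compound 4 (0.18 log units; within the scatter) leaves 3-fluorophenyl and 4-fluorophenyl unresolved, so these compounds show no graded trend across the three fluorophenyl groups: only the 2-fluorophenyl group of compound 3 stands apart. Nothing available here explains this difference.

Still open, on these data alone, is whether the separation belongs to fluorine itself or would also appear with a 2-chlorophenyl or 2-methylphenyl group on the shared core. Compound 2 differs from the fluorophenyl compounds in more than one place, so it cannot show how an unsubstituted phenyl group compares with them.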